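The source may report more compounds than this note shows. Statements on the series, on what has been measured and on what is new or still open speak of the compounds shown alone.

Three compounds share one core: compound 1 `O=C1NC(=S)S/C1=C\C=C\c1cc(Br)ccc1OCc1ccccc1Br`, compound 2 `O=C1NC(=S)S/C1=C\C=C\c1ccccc1OCc1ccccc1Br` and compound 3 `COc1cccc(COc2ccccc2/C=C/C=C2\SC(=S)NC2=O)c1`. In a functional assay on DLD-1 cells (Homo sapiens), read by microscopy and crystal violet staining, with a stated time of 20 h, tested at 10 ug/mL (on this read-out lower numbers stand for less inhibition and higher numbers for more inhibition at the one concentration tested (going by the name of the read-out)), compound 1 gives 71%, compound 2 gives 78% and compound 3 gives 82%. On these numbers compound 2 lies between the other two, both within the scatter: a number 7 percentage points higher from compound 1 to compound 2 (within the scatter) and a number 4 percentage points higher from compound 2 to compound 3 (within the scatter). Compound 4 `O=C1NC(=S)S/C1=C\C=C\c1ccccc1O` differs from compound 2 by hydrogen in place of 2-bromobenzyl on an oxygen on an aromatic ring. Neither measured step bears directly on this change, since one removes a bromo on an aromatic carbon and the other exchanges the group on the saturated chain carbon bound to the oxygen, while here the whole 2-bromobenzyl leaves. Both steps were within the scatter, so no step beyond it is expected in this assay, though the range is set wide. Compound 4 is estimated at 62% (range 35% to 85%), an expected step of a number 16 percentage points lower from compound 2 to compound 4 (beyond the scatter).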

Compound 4, a percentage reported as inhibition, at one concentration (the size of the read-out at that concentration, not a potency): 65%
For compound 4 the middle estimate is 3 percentage points below the measured one; low and high end bracket the measured number.
By their numbers in this assay, from the lowest: compounds 4, 1, 2 and 3 (each within the scatter of the next, the first and the last beyond it).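

In this assay, loss of the whole 2-bromobenzyl from the oxygen on the aromatic ring gives a number 13 percentage points lower from compound 2 to compound 4 (beyond the scatter), the only step shown that lies beyond the scatter. The read-out therefore responds to removing this group entirely, as it did not to the earlier changes to the group, yet compound 4, which lacks it, still gives 65% at the one concentration tested. Nothing available explains this step.

Going by these compounds, it remains open whether a methyl on that oxygen would match compound 2 or compound 4. On these data alone, a longer chain ending in an amine or a carboxylic acid also remains untested in these notes.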